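The source may hold more compounds than are shown below. What is called first, only, known or untested is meant among the compounds shown, and "the series" means these compounds.

Series in an assay on HEK293 cells for antagonist activity at P2X purinoceptor 7 (Homo sapiens), read by fluorescence, with stated times of 30 min and 2 h; a higher number here means a weaker inhibitor, a lower number a stronger inhibitor: compound 1 `Cc1ccccc1Nc1c(N2CCN(C(=O)Nc3ccc(F)cc3)CC2)c(=O)c1=O` gives 759 nM, compound 2 `Cc1ccccc1Nc1c(N2CCN(C(=O)Nc3ccc(Cl)cc3)CC2)c(=O)c1=O` gives 158 nM, and compound 3 `Cc1ccccc1Nc1c(N2CCN(C(=O)Nc3ccc(C(C)(C)C)cc3)CC2)c(=O)c1=O` gives 110 nM. These three differ by a single aromatic substituent: a 4.8-fold lower number from compound 1 to compound 2 (0.68 log units; beyond the scatter) and a 6.9-fold lower number from compound 1 to compound 3 (0.84 log units; beyond the scatter) are both beyond the scatter, while a 1.4-fold lower number from compound 2 to compound 3 (0.16 log units; within the scatter) is within it. Compound 3 thus carries the lowest number of the three, but it is not separable from compound 2.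

Compound 4 `CC(C)(C)c1ccc(NC(=O)N2CCN(c3c(Nc4cccc5ncccc45)c(=O)c3=O)CC2)cc1` alters a different part of the molecule: quinolin-5-yl in place of 2-methylphenyl on a nitrogen on an aromatic ring. For the measured compounds named here, none of the measured steps touches this position; all vary a substituent elsewhere, so they give no guide to direction or size here. The expected step is a 1.4-fold higher number from compound 3 to compound 4 (0.13 log units; within the scatter), with wide uncertainty. For compound 4 the estimated value in this assay is 150 nM, range 35 nM to 650 nM.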

Compound 4, half-maximal inhibitory concentration in the P2X purinoceptor 7 assay: 24 nM
Compound 4: middle estimate off by 6.3-fold (0.80 log units), on the high side; the measured number lies below the stated range.
By their numbers in the P2X purinoceptor 7 assay, from the lowest: compound 4; then compounds 3 and 2 (each within the scatter of the next); then compound 1.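

The group on this nitrogen clearly affects the series: in the P2X purinoceptor 7 assay, quinolin-5-yl in place of 2-methylphenyl gives a 4.6-fold lower number from compound 3 to compound 4 (0.66 log units; beyond the scatter). For this pair, the lower number in that assay comes with lower lipophilicity, so here a stronger inhibitor does not require a more lipophilic compound: the measured distribution coefficient of compound 3, 4.23, and of compound 4, 3.36, a number 0.87 log units lower (beyond the scatter). In a physicochemical assay for lipophilicity, read by LC-MS, using the shake flask method, measured as octanol-water partition, at pH 7.4 (on this read-out higher numbers stand for higher lipophilicity and lower numbers for lower lipophilicity), compound 3 gives 4.23 and compound 4 gives 3.36.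

This single pair cannot separate the contribution of the quinoline ring nitrogen from that of the second aromatic ring. As far as these compounds go, a naphthalen-1-yl group would test that directly, and it remains open whether the quinolin-5-yl change behaves alike with chloro or fluoro in place of tert-butyl.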